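From 4-aminopiperidin-1-yl to 4-hydroxypiperidin-1-yl: an expected step

A few compounds are considered here, and "the series" means these few. Any claim that something is new, unique, unknown or untested is made for them only; others in the source may bear on it.

Compound 1 `Nc1ncc(-c2ccc(C(=O)N3CCC(N)CC3)cc2)nc1-c1ccc(C(F)(F)F)cc1`: 88000 nM
Compound 2 `Nc1ncc(-c2ccc(C(=O)N3CC[C@@H](O)C3)cc2)nc1-c1ccc(C(F)(F)F)cc1`: 90000 nM
Compound 3 `Nc1ncc(-c2ccc(C(=O)N3CC[C@H](O)C3)cc2)nc1-c1ccc(C(F)(F)F)cc1`: 68000 nM

All three values come from a physicochemical assay for solubility, read by HPLC, using the shake flask method, in phosphate buffer, with a stated time of 2 h, at pH 6.5; on this read-out lower numbers stand for lower solubility and higher numbers for higher solubility. Compound 1 holds no separate place among them, as the steps of a 1.0-fold higher number from compound 1 to compound 2 (0.01 log units; within the scatter) and a 1.3-fold lower number from compound 1 to compound 3 (0.11 log units; within the scatter) both stay within the scatter. The same holds for the step of a 1.3-fold lower number from compound 2 to compound 3 (0.12 log units; within the scatter), which joins two compounds that differ only in configuration.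

Still to be measured is compound 4 `Nc1ncc(-c2ccc(C(=O)N3CCC(O)CC3)cc2)nc1-c1ccc(C(F)(F)F)cc1`, which keeps the core of compound 1 and changes one group: hydroxy in place of amino on a saturated ring carbon. Hydroxy stands in place of amino on a saturated ring carbon, so that 4-aminopiperidin-1-yl becomes 4-hydroxypiperidin-1-yl.

Going by the values given here, no measured pair makes exactly this change. The closest evidence is the replacement of 4-aminopiperidin-1-yl by 3-hydroxypyrrolidin-1-yl, which also exchanges amino for hydroxy but alters the ring as well. In compound 2 and compound 3 that replacement gave only the two small steps above, a 1.0-fold higher number from compound 1 to compound 2 (0.01 log units; within the scatter) and a 1.3-fold lower number from compound 1 to compound 3 (0.11 log units; within the scatter). On that basis, no step beyond the scatter is expected in this assay, and the expected step is a 1.2-fold lower number from compound 1 to compound 4 (0.09 log units; within the scatter). Compound 4 is estimated at 72000 nM, with an expected range from 36000 nM to 115000 nM.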

Compound 4, solubility: 19000 nM
Compound 4: the middle estimate sits 3.8-fold (0.58 log units) above what was measured; the measured number lies below the stated range.
By their numbers in this assay, from the lowest: compound 4; then compounds 3, 1 and 2 (each within the scatter of the next).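

In this assay, the exchange of amino for hydroxy on this saturated ring carbon of the six-membered ring proves not to be a neutral one, giving a 4.6-fold lower number from compound 1 to compound 4 (0.67 log units; beyond the scatter), whereas the earlier compounds had shown no step beyond the scatter. Hydroxy alone does not set the number, as compounds bearing 3-hydroxypyrrolidin-1-yl on the same carbonyl stand well clear of the 4-hydroxypiperidin-1-yl compound, with a 4.7-fold lower number from compound 2 to compound 4 (0.68 log units; beyond the scatter) and a 3.6-fold lower number from compound 3 to compound 4 (0.55 log units; beyond the scatter). Among these four compounds, then, the read-out depends on the ring and the group taken together, and the earlier comparison, which changed both at once, could not be carried over to a change of the group alone.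

Nothing given here bears on why the number falls with this change. As far as these compounds go, it remains open whether a methoxy group, a methylamino group or a carboxylic acid on this ring carbon would stay with compound 1 or fall with compound 4, and where 3-aminopyrrolidin-1-yl on the same carbonyl would stand.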